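The compounds below may be only part of what the source reports. "The series", "measured", "known", "first", "only" and "open" are said of these compounds alone.

In a functional assay on RAW264.7 cells (Mus musculus) for inhibition, read by Griess assay, with stated times of 1 h and 24 h (on this read-out lower numbers stand for stronger inhibition and higher numbers for weaker inhibition), compound 2 `COc1cc(/C=C/c2nc(NCc3ccccc3)c3sccc3n2)cc(OC)c1OC` gives 8260 nM, and compound 1 `COc1cc(/C=C/c2nc(Nc3ccc(C(F)(F)F)cc3)c3sccc3n2)cc(OC)c1OC` gives 9360 nM; these two numbers lie within the scatter of each other, so compound 2 does not stand apart from compound 1 on what has been measured. Among the measured compounds shown here, the only step measured so far, a 1.1-fold lower number from compound 1 to compound 2 (0.05 log units; within the scatter), swapped one group on the nitrogen on an aromatic ring for another and left the number essentially where it was. Compound 3 `COc1cc(/C=C/c2nc(NCc3ccncc3)c3sccc3n2)cc(OC)c1OC` takes the change one ring further: pyridin-4-yl in place of phenyl on a saturated chain carbon bound to a nitrogen on an aromatic ring. For the measured compounds named here, no measured step alters the ring at this place, so the sole guide is that the earlier exchange on the same nitrogen, from compound 1 to compound 2, produced no shift beyond the scatter. The expected step, a 1.0-fold higher number from compound 2 to compound 3 (0.01 log units; within the scatter), is therefore one that stays within the scatter. Compound 3 is estimated at 8500 nM, with a range from 4000 nM to 18000 nM.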

Compound 3, half-maximal inhibitory concentration: 6350 nM
Compound 3: the middle estimate sits 1.3-fold (0.13 log units) above what was measured, and the stated range covers the measured number.
By their numbers in this assay, from the lowest: compounds 3, 2 and 1 (each within the scatter of the next).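

Swapping phenyl for pyridin-4-yl on the saturated chain carbon adds one hydrogen-bond acceptor and gives a 1.3-fold lower number from compound 2 to compound 3 (0.11 log units; within the scatter) in this assay, so a ring nitrogen at this place does not separate the two compounds. The wider exchange on the same nitrogen, which gives a 1.5-fold lower number from compound 1 to compound 3 (0.17 log units; within the scatter), also stays within the scatter, so all three groups seen on this nitrogen leave the number in a single band, with no group standing apart. Nothing at hand offers an explanation for this flat result.

The compounds shown leave open whether pyridin-3-yl, pyridin-2-yl or a longer chain such as 2-phenylethyl would move the number beyond the scatter. They also leave open whether a carboxylic acid or an amine such as morpholine at this place would do so.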